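From compound 3 to compound 4: a substituent swap

The source may report more compounds than this note shows. Statements on the series, on what has been measured and on what is new or still open speak of the compounds shown alone.

Each value below is a limit in an ADME assay on MDBK cells (Bos taurus) for cytotoxicity (on this read-out lower numbers stand for higher toxicity in this test and higher numbers for lower toxicity in this test), and not a number
Compound 1 `Fc1cccc(F)c1Cn1ccc2nc(-c3c(F)cccc3F)nc-2c1` gives > 100000 nM
Compound 2 `Cc1ccn(Cc2c(F)cccc2F)c2nc(-c3c(F)cccc3F)nc1-2` gives > 100000 nM
Compound 3 `Cc1cccc(Cn2ccc3nc(-c4ccccc4)nc-3c2)c1` gives > 100000 nM

Compound 3 stands at a limit and not at a number (> 100000 nM). It shares that place with the other two measured compounds (the limit of > 100000 nM in this assay, at which 3 of the 3 values shown sit). Compound 4 `Clc1ccccc1Cn1ccc2nc(-c3ccccc3)nc-2c1` carries 2-chlorophenyl in place of 3-methylphenyl on a saturated chain carbon bound to an aromatic nitrogen. Going by the values given here, no step between measured compounds is available to size such a change in this assay. The expected step is none beyond the usual scatter (a number no higher from compound 3 to compound 4 (the limit leaves the size open)). That expectation rests on compound 3 (> 100000 nM), itself only a limit. The estimate for compound 4 is 100000 nM (expected range 40000 nM to 150000 nM), and a reading at the limit again is likely.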

Compound 4, half-maximal cytotoxic concentration: > 100000 nM
Compound 4: no number, only a limit; the forecaster's own chance of this, stated with the estimate: 75%; the middle value sits exactly at the limit.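

Going by these compounds alone, compound 3 and compound 4 both stand at a limit in this assay, and no step between them can be read. The compounds shown leave open at what concentration any of them would become cytotoxic: the limit of > 100000 nM in this assay, at which 4 of the 4 values shown sit.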